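Alpha-keto tetrazoles as inhibitors of fatty-acid amide hydrolase

A few compounds are considered here, and "the series" means these few. Any claim that something is new, unique, unknown or untested is made for them only; others in the source may bear on it.

Of the compounds shown here, two have been measured in an assay on microsomes from brain for inhibition of Fatty-acid amide hydrolase 1 (Rattus norvegicus), read by fluorescence and HPLC, with a stated time of 60 min; on this read-out lower numbers stand for stronger inhibition and higher numbers for weaker inhibition. Compound 1 `CCCCCCCCc1ccc(OCC(=O)Cn2nnnc2C(=O)OCC)cc1` gives 940 nM there. Compound 2 `CC(Oc1ccc(Oc2ccc(F)cc2)cc1)C(=O)Cn1nnc(-c2ccccc2)n1` gives 24 nM, the lower of the two numbers; the gap to compound 1 lies beyond the usual scatter. Among the compounds with values here, no other pair differs in a single place, so no step within the measured set can be isolated.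

Compound 3 `CC(Oc1ccc(-c2ccccc2)cc1)C(=O)Cn1nnc(-c2ccccc2)n1` remains to be measured in this assay. It differs from compound 2 by phenyl in place of 4-fluorophenoxy on an aromatic carbon – phenyl in place of 4-fluorophenoxy on an aromatic carbon, para to a large group. The measured pair gives no guide to this kind of change. The step from compound 2 to compound 3 is expected to be small, a 1.7-fold higher number from compound 2 to compound 3 (0.22 log units; within the scatter), in either direction and not clearly beyond the scatter. Compound 3 is accordingly estimated at 40 nM, with a range from 8 nM to 200 nM.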

Compound 3, half-maximal inhibitory concentration: 15 nM
The estimate for compound 3 lay 2.7-fold (0.43 log units) above the measured number; low and high end bracket the measured number.
By their numbers in this assay, from the lowest: compounds 3 and 2 (each within the scatter of the next); then compound 1.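

In this assay, phenyl in place of 4-fluorophenoxy on an aromatic carbon, para to a large group, gives a 1.6-fold lower number from compound 2 to compound 3 (0.20 log units; within the scatter) and leaves compound 2 and compound 3 indistinguishable on this read-out. Within the data shown here, this is the first single-place change, and it shows that this position accepts the loss of the oxygen and the fluorine counted in the leaving group, together with its hydrogen-bond acceptor, without a change beyond the scatter. No measurement available here explains why the two groups read alike.

Still open, as far as these compounds go, is whether an amine, a carboxylic acid or a longer alkyl chain on this aromatic carbon would stay close to compound 3 at 15 nM or depart from it. Compound 2 and compound 3 differ from compound 1 in more than one place, so the reading of compound 1 at 940 nM cannot be assigned to any single change.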